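The source may hold more compounds than are shown below. What is called first, only, known or untested is meant among the compounds shown, and "the series" means these compounds.

Working notes on the series. In a functional assay on M21 cells (Homo sapiens) for antiproliferative activity, read by sulforhodamine B assay, with a stated time of 48 h (a lower number here means a stronger inhibitor, a higher number a weaker inhibitor), compound 1 (`COc1ccc(OS(=O)(=O)c2ccc(N3CCN(C)C3=O)cc2)cc1`) gives > 100000 nM, which is a limit of the assay and not a number. Compound 2 (`CN1CCN(c2ccc(S(=O)(=O)Oc3ccc(F)cc3)cc2)C1=O`) gives > 100000 nM, also a limit. The measured position of the series is therefore (the limit of > 100000 nM in this assay, at which 2 of the 2 values shown sit).

Compound 3 (`CCN1CCN(c2ccc(S(=O)(=O)Oc3ccc(OC)cc3)cc2)C1=O`) carries 3-ethyl-2-oxoimidazolidin-1-yl where compound 1 carries 3-methyl-2-oxoimidazolidin-1-yl: methyl in place of hydrogen on a saturated chain carbon bound to an amide-type nitrogen in a ring. Within the data shown here, the only measured step is a step that the two limits leave unreadable from compound 1 to compound 2, with fluoro in place of methoxy on an aromatic carbon. It is a different change and has no readable size, so it offers no magnitude or direction to carry over. No shift beyond the scatter is expected in this assay, and the expected step is a number no higher from compound 1 to compound 3 (the limit leaves the size open). For compound 3 the estimated value is 100000 nM, with an expected range of 40000 nM to 250000 nM, and another report as a limit is expected to be the likeliest outcome.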

Compound 3, half-maximal inhibitory concentration: 26000 nM
For compound 3 the middle estimate is 3.8-fold (0.59 log units) above the measured one; the whole stated range lies above it.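

In this assay the change from 3-methyl-2-oxoimidazolidin-1-yl to 3-ethyl-2-oxoimidazolidin-1-yl gives an at least 3.8-fold lower number from compound 1 to compound 3 (0.58 log units; beyond the scatter). Compound 3, at 26000 nM, is the only compound shown with a number rather than a limit, so this position, unlike the aromatic carbon changed in compound 2, has a readable effect on the result, at least in direction. Compound 1 and compound 2 remain limits, so the full size of this step is open and the step between those two cannot be read: the limit of > 100000 nM in this assay, at which 2 of the 3 values shown sit.

As far as these compounds go, whether fluoro in place of methoxy on the aromatic carbon would change the value of compound 3 remains open. Also open, from the compounds shown here alone, is whether a longer chain such as propyl or butyl, or a chain ending in an amine or a carboxylic acid, would lower the number further or reverse the step.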